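From quinolin-4-yl to quinolin-2-yl

This account rests on a few compounds, and the source may have more. Where it says the series, first, only, none or still open, it means among the compounds named here.

Compound 1 (`CC[C@H]1OC(=O)[C@H](C)[C@@H](O[C@H]2C[C@@](C)(OC)[C@@H](O)[C@H](C)O2)[C@H](C)[C@@H](O[C@@H]2O[C@H](C)C[C@H](N(C)C)[C@H]2OCCCNC(=O)CNc2ccnc3cc(Cl)ccc23)[C@](C)(O)C[C@@H](C)CN(C)[C@H](C)[C@@H](O)[C@]1(C)O`): > 10000 ug/mL
Compound 2 (`CC[C@H]1OC(=O)[C@H](C)[C@@H](O[C@H]2C[C@@](C)(OC)[C@@H](O)[C@H](C)O2)[C@H](C)[C@@H](O[C@@H]2O[C@H](C)C[C@H](N(C)C)[C@H]2OCCCNCc2ccnc3ccccc23)[C@](C)(O)C[C@@H](C)CN(C)[C@H](C)[C@@H](O)[C@]1(C)O`): > 10000 ug/mL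

Compound 1 reads > 10000 ug/mL in a physicochemical assay for solubility, at pH 4 (a lower number here means a less soluble compound, a higher number a more soluble compound), and this is a limit, not a number. Compound 2 reads > 10000 ug/mL in this assay and this too is only a limit. Compound 2 therefore stands at the limit of > 10000 ug/mL in this assay, at which 2 of the 2 values shown sit, and has no exact value.

Compound 3 (`CC[C@H]1OC(=O)[C@H](C)[C@@H](O[C@H]2C[C@@](C)(OC)[C@@H](O)[C@H](C)O2)[C@H](C)[C@@H](O[C@@H]2O[C@H](C)C[C@H](N(C)C)[C@H]2OCCCNCc2ccc3ccccc3n2)[C@](C)(O)C[C@@H](C)CN(C)[C@H](C)[C@@H](O)[C@]1(C)O`) carries quinolin-2-yl in place of quinolin-4-yl on a saturated chain carbon bound to an amine nitrogen. Going by the values given here, no measured step shows the effect of this swap, so no change beyond the usual scatter is expected in this assay in either direction. The expected step of a number no higher from compound 2 to compound 3 (the limit leaves the size open) is therefore small. Compound 3 is estimated at 10000 ug/mL with an expected range of 4000 ug/mL to 20000 ug/mL in this measurement.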

Compound 3, solubility: > 10000 ug/mL
Compound 3 ended at the assay's limit; the forecaster's own chance of this, stated with the estimate: 80%; the middle value sits exactly at the limit.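

In this assay compound 3 gives > 10000 ug/mL, which is a limit and not a number. Going by these compounds alone, compound 2 sits at the same limit, so no step between compound 2 and compound 3 can be read. Going by these compounds, whether swapping quinolin-4-yl for quinolin-2-yl changes the read-out at all remains open.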